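A few compounds are considered here, and "the series" means these few. Any claim that something is new, unique, unknown or untested is made for them only; others in the source may bear on it.

Measured in a functional assay on PC-3 cells (Homo sapiens) for antiproliferative activity, read by MTT assay, with a stated time of 48 h; on this read-out lower numbers stand for stronger inhibition and higher numbers for weaker inhibition:
compound 1 `COc1cc(/C=C/C(C)=O)ccc1OCc1cn(-c2c(Cl)cccc2Cl)nn1` gives 3070 nM
compound 2 `COc1cc(/C=C/C(C)=O)ccc1OCc1cn(-c2ccccc2OC)nn1` gives 2050 nM
compound 3 `COc1cc(/C=C/C(C)=O)ccc1OCc1cn(-c2ccc([N+](=O)[O-])cc2)nn1` gives 46700 nM

Compound 3 carries the highest number of the three. The steps from the other two aryl substituents on the triazole nitrogen to the nitro-bearing ring are both large: a 15-fold higher number from compound 1 to compound 3 (1.18 log units; beyond the scatter) and a 23-fold higher number from compound 2 to compound 3 (1.36 log units; beyond the scatter). Between compounds 1 and 2 the step is small, a 1.5-fold lower number from compound 1 to compound 2 (0.18 log units; within the scatter).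

Compound 4 `COc1cc(/C=C/C(C)=O)ccc1OCc1cn(-c2ccc(-c3ccccc3)cc2)nn1` differs from compound 3 in one place: phenyl in place of nitro on an aromatic carbon. For the measured compounds named here, no measured step tests a phenyl at this position, so only the removal of the nitro group is informative; both steps to compound 3 suggest that leaving it should bring the number down, roughly into the range of compounds 1 and 2. Compound 4 is therefore expected to give 4000 nM in this assay, with a range of 1500 nM to 15000 nM, that is an estimated step of a 12-fold lower number from compound 3 to compound 4 (1.07 log units; beyond the scatter).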

Compound 4, half-maximal inhibitory concentration: 56800 nM
Beside the measured number, compound 4's estimate is 14-fold (1.15 log units) below it; the whole stated range lies below it.
By their numbers in this assay, from the lowest: compounds 2 and 1 (each within the scatter of the next); then compounds 3 and 4 (each within the scatter of the next).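

In this assay phenyl in place of nitro, on an aromatic carbon para to a large group, gives no change beyond the scatter (a 1.2-fold higher number from compound 3 to compound 4 (0.09 log units; within the scatter)). The high number of compound 3 is therefore not specific to nitro: two very different groups at this place read alike, and losing nitro alone does not reach the numbers of compound 1 and compound 2. No available evidence bears on this result.

From the compounds shown here alone, whether an amine or a methoxy group at this place would read lower remains open, as does the number for the ring with no group there.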